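The source may hold more compounds than are shown below. What is called first, only, known or untested is meant among the compounds shown, and "the series" means these compounds.

Measured so far in a functional assay on L1210 cells (Mus musculus) for inhibition; a higher number here means a weaker inhibitor, a lower number a stronger inhibitor:

- Compound 1 `CCNCCCNCCCCNCCCN`: 1700 nM
- Compound 2 `CCNCCCCNCCCCNCCCCN`: 1100 nM

Going by the values given here, with only two measured compounds, there is very little to compare. Compound 2 gives 1100 nM in this assay, and this lies within the usual scatter of the value found for compound 1 at 1700 nM. The two compounds therefore cannot be ranked on these numbers.

The next compound to be tested is compound 3 `CCNCCCCNCCCCNCCCNCC`, which has no measured value yet. Starting from compound 2, the change puts ethylamino in place of aminomethyl on a saturated chain carbon, three bonds along the chain from an amine nitrogen.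

Among the compounds with values here, no pair of measured compounds shows this same change, so the data offer no direct guide to its effect. The closest evidence is that compound 1, at 1700 nM, and compound 2, at 1100 nM, sit within the scatter of each other. A change no larger than the scatter, with no clear direction, is therefore expected in this assay. The estimated step of a 1.1-fold higher number from compound 2 to compound 3 (0.04 log units; within the scatter) reflects that expectation.

The estimated value for compound 3 is 1200 nM, with an expected range of 400 nM to 3500 nM.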

Compound 3, inhibition constant: 8000 nM
Compound 3: the middle estimate sits 6.7-fold (0.82 log units) below what was measured; measured number above the stated range.
By their numbers in this assay, from the lowest: compounds 2 and 1 (each within the scatter of the next); then compound 3.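

In this assay, ethylamino in place of aminomethyl on a saturated chain carbon, three bonds along the chain from an amine nitrogen, gives a 7.3-fold higher number from compound 2 to compound 3 (0.86 log units; beyond the scatter) and so weakens inhibition beyond the scatter. Going by these compounds alone, this is the first change to produce a clear difference, since the earlier pair could not be ranked, and it shows that this end of the chain does not accept every replacement equally. The step of (ethylamino)methyl in place of amino at the same kind of place points the same way, with a 4.7-fold higher number from compound 1 to compound 3 (0.67 log units; beyond the scatter) as the printed change, while no measurement shown here gives a reason for the loss.

The compounds shown leave open whether the loss follows from the ethyl group on the nitrogen itself or from the altered length of the chain up to that nitrogen. A methylamino group at this place, or a longer propylamino group, would help separate these two readings by showing whether the number keeps rising as the group on the nitrogen grows.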